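A methoxyphenyl swap on compound 2

The source may report more compounds than this note shows. Statements on the series, on what has been measured and on what is new or still open speak of the compounds shown alone.

Two compounds have been measured so far in a functional assay on BGC-823 cells (Homo sapiens) for antiproliferative activity, read by MTT assay, with a stated time of 48 h; on this read-out lower numbers stand for stronger inhibition and higher numbers for weaker inhibition
Compound 1 `CCn1cc(-c2ccc(F)cc2)c(=O)c2cc(F)c(N3CCNCC3)cc21` gives 69600 nM
Compound 2 `O=c1c(-c2ccc(F)cc2)cn(C2CC2)c2cc(N3CCNCC3)c(F)cc12` gives 15100 nM

Compound 2 holds the lower of these two numbers. Compound 3 `COc1cccc(-c2cn(C3CC3)c3cc(N4CCNCC4)c(F)cc3c2=O)c1` carries 3-methoxyphenyl in place of 4-fluorophenyl on an aromatic carbon. Among the measured compounds shown here, the only measured step (a 4.6-fold lower number from compound 1 to compound 2 (0.66 log units; beyond the scatter)) was modest and put cyclopropyl in place of ethyl on an aromatic nitrogen, a different place, so no measured step bears directly on this change. No step beyond the scatter is therefore expected in this assay in either direction. The expected step (a 1.2-fold lower number from compound 2 to compound 3 (0.07 log units; within the scatter)) stays within the scatter. Compound 3 is estimated at 13000 nM (expected range from 4500 nM to 40000 nM).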

Compound 3, half-maximal inhibitory concentration: 690 nM
Compound 3: the middle estimate sits 19-fold (1.28 log units) above what was measured; measured number outside the range, below it.
By their numbers in this assay, from the lowest: compound 3; then compound 2; then compound 1.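

In this assay, 3-methoxyphenyl in place of 4-fluorophenyl on the aromatic carbon two atoms from the ring nitrogen gives a 22-fold lower number from compound 2 to compound 3 (1.34 log units; beyond the scatter) as a large step. The earlier compounds both carried 4-fluorophenyl, so only now is this position shown to respond strongly to a change of aryl group. Nothing measured here accounts for the step. The swap changes both the substituent and where it sits on the phenyl ring, and the compounds shown do not separate the two. On these data alone, how 4-methoxyphenyl, 3-fluorophenyl or 3-aminophenyl would read at this position remains open.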